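Nitrile to Carboxylic Acid at the Chain End

The compounds below may be only part of what the source reports. "The series", "measured", "known", "first", "only" and "open" are said of these compounds alone.

Of the compounds shown here, three have been measured in an assay on isolated protein for inhibition of leukotriene B4 receptor 1 (Homo sapiens), tested at 10 uM; on this read-out lower numbers stand for less inhibition and higher numbers for more inhibition at the one concentration tested (going by the name of the read-out). Compound 1 `CCCc1cc(C(C)=O)c(O)cc1OCCCCC#N` gives 84%. Compound 2 `CCc1cc(C(C)=O)c(O)cc1OCCCCCC(C)(C)C#N` gives 85%, and compound 3 `CCc1cc(C(C)=O)c(O)cc1OCCCCCC(C)(C)C(=O)O` gives 104%. The values of compound 1 and compound 2 lie within the scatter of each other. Compound 1 and compound 2 differ in more than one place, and the difference between the two cores is not broken down here. Compound 3 differs from compound 2 by a single change, (carboxy in place of cyano on a saturated chain carbon bound to three saturated chain carbons), and this produced a number 19 percentage points higher from compound 2 to compound 3 (beyond the scatter). Compound 4 `CCCc1cc(C(C)=O)c(O)cc1OCCCCC(=O)O` has not yet been measured; it differs from compound 1 by carboxy in place of cyano on a saturated chain carbon, four bonds along the chain from an oxygen on an aromatic ring. Within the data shown here, this is the same kind of change as the one from compound 2 to compound 3, but not the same: there the place is on a saturated chain carbon bound to three saturated chain carbons, whereas here it is on a saturated chain carbon, four bonds along the chain from an oxygen on an aromatic ring. For compound 4 a step of similar size, a number 16 percentage points higher from compound 1 to compound 4 (beyond the scatter), is expected because the same kind of change gave a number 19 percentage points higher from compound 2 to compound 3 (beyond the scatter). Compound 4 is therefore estimated at 100%, likely between 88% and 110%.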

Compound 4, a percentage reported as inhibition, at one concentration (the size of the read-out at that concentration, not a potency): 11%
For compound 4 the middle estimate is 89 percentage points above the measured one, and the stated range ends above it.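

In this assay, carboxy in place of cyano gave a number 73 percentage points lower from compound 1 to compound 4 (beyond the scatter), whereas the same kind of change on the other core gave a number 19 percentage points higher from compound 2 to compound 3 (beyond the scatter), so the two steps run in opposite directions: the same change on two cores in this assay, a number 19 percentage points higher (beyond the scatter) from compound 2 to compound 3 and a number 73 percentage points lower (beyond the scatter) from compound 1 to compound 4, 92 percentage points apart, beyond the scatter of two such steps

This shows that, in this series, the step measured for this change on one core cannot simply be carried over to another core. Among these compounds, it does not show which structural difference sets the outcome, since compound 1 and compound 2 differ in more than one place and only two pairs of compounds are available, too few to support a general rule.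

From the compounds shown here alone, whether a methyl ester or a primary amide at the chain end would behave like the nitrile or like the carboxylic acid on either core remains open. Also open, going by these compounds, is which difference between the cores matters, a question that nitrile and carboxylic acid pairs differing from these cores in only one place could address.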